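Methoxy to Hydroxy: From Compound 2 to Compound 4

The source may hold more compounds than are shown below. What is called first, only, known or untested is meant among the compounds shown, and "the series" means these compounds.

In a functional assay on Malme-3M cells (Homo sapiens) for inhibition, read by sulforhodamine B assay, with a stated time of 48 h (on this read-out higher numbers stand for lower toxicity in this test and lower numbers for higher toxicity in this test), compound 2 `COc1cc(C)cc(-c2nn(CC#N)cc2-c2ccnc(-c3ccc(N(C)C)cc3)c2)c1` is known only by a limit, > 100000 nM. Compound 1 `COc1cc(C)cc(-c2c(-c3ccnc(-c4ccc(N(C)C)cc4)c3)cnn2CC#N)c1` likewise gives only a limit, > 100000 nM. Compound 3 `COc1cc(C)cc(-c2nn(CC#N)cc2-c2ccc(-c3cccc(C(C)=O)c3)nc2)c1` also sits at a limit, > 100000 nM. Within the data shown here, all three measured compounds thus share the same boundary, (the limit of > 100000 nM in this assay, at which 3 of the 3 values shown sit), and no step between measured compounds carries a number on both sides, so no measured comparison of size is available.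

Compound 4 `Cc1cc(O)cc(-c2nn(CC#N)cc2-c2ccnc(-c3ccc(N(C)C)cc3)c2)c1` has not yet been tested in this assay. It differs from compound 2 in one place: hydrogen in place of methyl on an oxygen on an aromatic ring. Cut one bond further out, this reads methoxy to hydroxy.

All shown values rest at the limit, so the data give no direction for this change. Compound 4 is therefore expected to stand near the same boundary, the expected step of a number no higher from compound 2 to compound 4 (the limit leaves the size open) amounting to no change beyond the scatter. The estimate for compound 4 is 100000 nM, spanning from 30000 nM to 300000 nM.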

Compound 4, concentration lethal to 50% of the cells: > 100000 nM
Compound 4 was reported as a limit; the forecaster's own chance of this, stated with the estimate: 75%; the middle value lies on the limit itself.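

In this assay compound 4 gives > 100000 nM, which is a limit. Compound 2 is also known only by a limit, so the step between the two compounds cannot be read. The compounds shown leave open whether any of their structural differences alters this read-out, since all rest at one boundary: the limit of > 100000 nM in this assay, at which 4 of the 4 values shown sit.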